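Allyl-phenol series: growth inhibition on HepG2 cells

A few compounds are considered here, and "the series" means these few. Any claim that something is new, unique, unknown or untested is made for them only; others in the source may bear on it.

Measured compounds in a functional assay on HepG2 cells (Homo sapiens) for inhibition, read by MTT assay, with a stated time of 72 h, tested at 50 uM; a lower number here means less inhibition of growth, a higher number more inhibition of growth at the concentration tested:
compound 1 `C=CCc1ccc(OCc2cn(-c3ccccc3CO)nn2)c(O)c1`, 8.5%
compound 2 `C=CCc1cc(O)c(O)c(CN2CCC(Cc3ccccc3)CC2)c1`, 84%
compound 3 `C=CCc1ccc(OCc2cn(-c3ccc(C(=O)c4ccccc4)cc3)nn2)c(O)c1`, 16.2%

Compound 3 stands second highest of the three numbers in this assay. Its nearest neighbour is compound 1, whose value lies lower by an amount within the usual scatter, so the two are not distinguishable here. Compound 2 gives a much higher number, beyond the scatter, but it differs from compound 3 in more than one place, so no single step can be read from that pair.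

Compound 4 `C=CCc1ccc(OCc2cn(-c3ccc(C#N)cc3)nn2)c(O)c1` is not yet measured in this assay. It differs from compound 3 in one place: cyano in place of benzoyl on an aromatic carbon.

Among the measured compounds shown here, no single-point step between measured compounds exists in this set, so the size of the step in this assay from compound 3 to compound 4 is open. The two measured compounds sharing the core of compound 3, compound 1 and compound 3, both sit low in this assay, and the step to compound 4 is expected to stay within the scatter, a number 3.2 percentage points lower from compound 3 to compound 4 (within the scatter), with no clear direction. Compound 4 is therefore estimated to give 13%, within a range from 3% to 28%.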

Compound 4, percent growth inhibition at one concentration: 12.1%
The estimate for compound 4 lay 0.9 percentage points above the measured number; the range from low to high includes it.
By their numbers in this assay, from the lowest: compounds 1, 4 and 3 (each within the scatter of the next); then compound 2.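

In this assay, cyano in place of benzoyl on the aromatic carbon gives a number 4.1 percentage points lower from compound 3 to compound 4 (within the scatter), so exchanging 8 heavy atoms, including a six-membered aromatic ring of carbon only, for 2 heavy atoms and no ring produces no distinguishable change at this position. The whole substituent on the aromatic nitrogen can also be exchanged without a distinguishable change: 4-cyanophenyl in place of 2-(hydroxymethyl)phenyl gives a number 3.6 percentage points higher from compound 1 to compound 4 (within the scatter). No measured property bears on either step, and neither can be given a cause.

As far as these compounds go, how an amine or a carboxylic acid on that aromatic carbon would read in this assay stays open, as does whether any group there can lift the number clear of the scatter around these three compounds. Among the compounds shown here, also open is what separates them from compound 2 at 84%, which differs from each of them in more than one place and is reached by no single step.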